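The source may report more compounds than this note shows. Statements on the series, on what has been measured and on what is new or still open speak of the compounds shown alone.

Compound 3 `Cc1nn(C(=O)C2CCCC2)c(N)c1-c1ccc(Cl)c(Cl)c1` stands at the edge of what this study could read: in an assay on Sf9 cells for inhibition of inhibitor of nuclear factor kappa-B kinase subunit epsilon (Homo sapiens), read by ADP-Glo, with a stated time of 60 min (on this read-out higher numbers stand for weaker inhibition and lower numbers for stronger inhibition), compound 3 gives > 100000 nM, which is a limit of the assay and not a number. Compound 1 `CCC(=O)n1nc(C)c(-c2ccc(Cl)c(Cl)c2)c1N` gives > 100000 nM in this assay, again a limit. Compound 2 `Cc1nn(C(=O)C2CCC2)c(N)c1-c1ccc(Cl)c(Cl)c1` gives > 100000 nM, likewise a limit. The three measured steps, a step that the two limits leave unreadable from compound 1 to compound 2, a step that the two limits leave unreadable from compound 1 to compound 3 and a step that the two limits leave unreadable from compound 2 to compound 3, therefore cannot be sized, because every value sits at the limit of > 100000 nM in this assay, at which 3 of the 3 values shown sit. Compound 4 `Cc1nn(C(=O)C2CCCCC2)c(N)c1-c1ccc(Cl)c(Cl)c1` differs from compound 3 by cyclohexyl in place of cyclopentyl on a carbonyl carbon. Since each earlier change at the carbonyl carbon left the reading at the limit, compound 4 is expected to stay there too, at an estimated 100000 nM, between 30000 nM and 300000 nM. The expected step from compound 3 is a number no higher from compound 3 to compound 4 (the limit leaves the size open).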

Compound 4, half-maximal inhibitory concentration: > 100000 nM
Compound 4 gave a limit, no number; the forecaster's own chance of this, stated with the estimate: 85%; the middle value lies on the limit itself.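

Among the compounds shown here, no step from compound 1, compound 2 or compound 3 to compound 4 can be read, because all four readings are a limit and not a number: the limit of > 100000 nM in this assay, at which 4 of the 4 values shown sit. The compounds shown leave open how strongly any of them inhibits, and whether any group on the carbonyl carbon would give a readable number.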